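Fluoro for Chloro: Estimating Compound 4 from Compound 1

This account rests on a few compounds, and the source may have more. Where it says the series, first, only, none or still open, it means among the compounds named here.

Compound 1 `CC1CCN(c2c(S(=O)(=O)c3ccc(F)c(Cl)c3)cnc3cc(Cl)ccc23)CC1` is the reference point here. In an assay on isolated protein for displacement of a labelled ligand from metabotropic glutamate receptor 5 (Homo sapiens), with a stated time of 60 min, tested at 1 uM (on this read-out higher numbers stand for more inhibition at the one concentration tested (going by the name of the read-out) and lower numbers for less inhibition), compound 1 gives 94%. Compound 3 `CC1CCN(c2c(S(=O)(=O)c3ccc(F)c(Cl)c3)cnc3cc(F)ccc23)CC1` gives 94%, and compound 2 `COc1ccc2ncc(S(=O)(=O)c3ccc(Cl)c(Cl)c3)c(N3CCC(C)CC3)c2c1` gives 87%. Compound 1 thus stands level with compound 3 at the digits shown, the two together giving the highest of the three numbers, and compound 2 sits within the scatter of both, so no ordering among the three can be claimed.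

Compound 4 `CC1CCN(c2c(S(=O)(=O)c3ccc(F)c(F)c3)cnc3cc(Cl)ccc23)CC1` is the unmeasured compound. It differs from compound 1 in a single place: fluoro in place of chloro on an aromatic carbon. Cut one bond further out, the change reads 3-chloro-4-fluorophenyl to 3,4-difluorophenyl.

Among the measured compounds shown here, one measured step bears directly on this kind of swap. The step of no change at the digits printed from compound 1 to compound 3 (within the scatter) is the same exchange of fluoro for chloro on an aromatic carbon, made on a different aromatic carbon of the shared core, and it left the read-out flat. For the measured compounds named here, with only that one step as guidance, no movement beyond the scatter is expected in this assay for compound 4.

The estimated step of a number 3 percentage points lower from compound 1 to compound 4 (within the scatter) is therefore expected to be essentially flat. Compound 4 is estimated at 91%, with a range from 80% to 98%.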

Compound 4, a percentage reported as inhibition, at one concentration (the size of the read-out at that concentration, not a potency): 90%
Estimate against measurement, compound 4: 1 percentage points above; the range from low to high includes it.
By their numbers in this assay, from the lowest: compounds 2, 4, 1 and 3 (each within the scatter of the next).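

In this assay, the exchange of chloro for fluoro has now been tested on the six-membered aromatic ring of carbon only, at the place ortho to a fluoro group and meta to a large group, giving a number 4 percentage points lower from compound 1 to compound 4 (within the scatter). The earlier step of this kind, no change at the digits printed from compound 1 to compound 3 (within the scatter), was made on a different aromatic carbon of the shared core. Together, the two steps show that the read-out stays within the scatter for this exchange at both places, though this claim reaches no further than these compounds.

As far as these compounds go, both steps trade one halogen for another, so what an amine, a carboxylic acid or a longer chain would do at this place remains open. Each number is also a reading at one concentration rather than a potency, so a real difference in potency between compound 1 and compound 4 could lie hidden behind their similar readings in this assay. Nothing available here helps explain why the read-out holds at this place.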